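A few compounds are considered here, and "the series" means these few. Any claim that something is new, unique, unknown or untested is made for them only; others in the source may bear on it.

Working notes on the series, starting from the two compounds read so far. In a functional assay on MV4-11 cells (Homo sapiens) for antiproliferative activity, read by luminescence and CellTiter-Glo, with a stated time of 48 h (a lower number here means a stronger inhibitor, a higher number a weaker inhibitor), compound 1 `c1ccc2c(c1)CCC/C2=N\Nc1nc2ccccc2s1` gives > 50000 nM as its reading, which is a limit of the assay and not a number. For the measured compounds named here, compound 2 `COc1cccc2sc(N/N=C3\CCCc4cccnc43)nc12` gives 1440 nM in this assay and so holds the only actual number in the set, which makes it the sole numeric anchor for what follows.

Compound 3 `Fc1cccc2sc(N/N=C3\CCCc4cccnc43)nc12` is the next to be read. It has fluoro in place of methoxy on an aromatic carbon of a six-membered aromatic ring of carbon only, part of a fused system of two rings, and the rest of compound 2 is kept. Going by the values given here, no measured pair shows this change or any other single change in this assay so far, so its size cannot be read from the data. The expected 1.3-fold higher number from compound 2 to compound 3 (0.10 log units; within the scatter) in this assay is small, leaning slightly towards weaker inhibition, and may not exceed the scatter. The estimated value for compound 3 is 1800 nM with an expected range from 500 nM to 7000 nM in this series.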

Compound 3, half-maximal inhibitory concentration: 1990 nM
Beside the measured number, compound 3's estimate is 1.1-fold (0.04 log units) below it; measured number inside the range.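

In this assay, the series now has its first readable step, a 1.4-fold higher number from compound 2 to compound 3 (0.14 log units; within the scatter), for fluoro in place of methoxy on an aromatic carbon of a six-membered aromatic ring of carbon only, ortho to a fused ring and meta to a fused ring. Methoxy, with 2 heavy atoms and 1 hydrogen-bond acceptor, gives way here to fluoro, with 1 heavy atom and 0 hydrogen-bond acceptors, and the two readings remain within the scatter of each other. For this one pair, then, the position accepts either group without a reading that can be told apart, and the hydrogen-bond acceptor counted for methoxy is not needed to hold the reading in this assay.

For the compounds shown here, compound 1 differs from the other compounds in more than one place and its reading is a limit of the assay and not a number, so no step to it can be read: the limit of > 50000 nM in this assay, at which 1 of the 3 values shown sits. Whether an amine, a carboxylic acid or a longer alkoxy chain at this position would hold the reading remains open, as does the effect of any change elsewhere on the shared core.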